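This account rests on a few compounds, and the source may have more. Where it says the series, first, only, none or still open, it means among the compounds named here.

Measured compounds:

Compound 1 `Cc1cc(-c2c(O)nc3cc(Cl)c(C(=O)Nc4ccncn4)cc3c2OCC[C@@H]2CCCCN2)cc(C)c1C` gives 0.3 nM in an assay on isolated protein for inhibition of Gonadotropin-releasing hormone receptor (Homo sapiens); a higher number here means a weaker inhibitor, a lower number a stronger inhibitor.
Compound 2 `Cc1cc(C)cc(-c2c(O)nc3cc(Cl)c(NC(=O)c4cnccn4)cc3c2OCC[C@@H]2CCCCN2)c1` gives 2 nM in this assay.

Within the data shown here, of the two numbers in hand, compound 2 carries the higher one; the only neighbour is compound 1, whose value is lower by a margin beyond the scatter. Compound 3 `Cc1cc(C)cc(-c2c(O)nc3cc(Cl)c(NC(=O)Nc4cncnc4)cc3c2OCC[C@@H]2CCCCN2)c1` is not yet measured. It differs from compound 2 in one place: (pyrimidin-5-yl)amino in place of pyrazin-2-yl on a carbonyl carbon. Among the measured compounds shown here, no measured pair isolates this change, so the size of the step rests on expectation alone. The change keeps a six-membered aromatic ring with 2 hetero atoms on the carbonyl carbon and adds one hydrogen-bond donor; a step of modest size is expected, within or only slightly beyond the scatter, with no firm direction. From compound 2 the estimated step to compound 3 is a 1.5-fold higher number from compound 2 to compound 3 (0.18 log units; within the scatter). Compound 3 is expected to give about 3 nM in this assay, with a range from 0.8 nM to 12 nM.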

Compound 3, half-maximal inhibitory concentration: 57 nM
For compound 3 the middle estimate is 19-fold (1.28 log units) below the measured one; the whole stated range lies below it.
By their numbers in this assay, from the lowest: compound 1; then compound 2; then compound 3.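

In this assay the exchange of pyrazin-2-yl for (pyrimidin-5-yl)amino on a carbonyl carbon gives a 29-fold higher number from compound 2 to compound 3 (1.45 log units; beyond the scatter) and so shows that this position does not tolerate every group with a six-membered aromatic ring with 2 hetero atoms. Keeping that ring count does not preserve the value here, even though the entering group differs by only one heavy atom and one hydrogen-bond donor. Nothing available explains the size of this step.

The ring exchange and the added amino link change together, so the compounds shown do not assign the loss to either one. Open as well is where (pyrazin-2-yl)amino or pyrimidin-5-yl would fall on the same carbonyl carbon, as either group would separate the two changes.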